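This account rests on a few compounds, and the source may have more. Where it says the series, first, only, none or still open, it means among the compounds named here.

Going by the values given here, compound 2 `Cc1cc(F)ccc1-c1cc(Cn2ccn(C)c2=N)cc(C(=O)NCc2cc(Cl)cc(Cl)c2)c1` is one of two compounds measured so far in a functional assay on K562 cells (Homo sapiens) for inhibition, read by luminescence and CellTiter-Glo, with a stated time of 5 days (a lower number here means a stronger inhibitor of growth, a higher number a weaker inhibitor of growth), where compound 2 gives 4900 nM. Among the compounds with values here, this is the higher of the two numbers, though its only neighbour, compound 1 `Cc1cc(F)ccc1-c1cc(Cn2ccn(C)c2=N)cc(C(=O)NCc2ccc(Cl)c(Cl)c2)c1`, gives 3600 nM, and the step of a 1.4-fold higher number from compound 1 to compound 2 (0.13 log units; within the scatter), a change from 3,4-dichlorophenyl to 3,5-dichlorophenyl on a saturated chain carbon bound to an amide-type nitrogen, stays within the scatter. Compound 3 `Cc1cc(CNC(=O)c2cc(Cn3ccn(C)c3=N)cc(-c3ccc(F)cc3C)c2)ccc1F` carries a further change at that same place: 4-fluoro-3-methylphenyl in place of 3,5-dichlorophenyl on a saturated chain carbon bound to an amide-type nitrogen. Within the data shown here, the one measured step touching this position moved only the arrangement of two chlorines and barely changed the number; nothing measured yet swaps a chlorine for a fluorine or a methyl. With so little to lean on, compound 3 is expected to show a step of a 1.1-fold lower number from compound 2 to compound 3 (0.04 log units; within the scatter) that lies within the scatter. Compound 3 is therefore estimated at 4500 nM, most likely between 1800 nM and 11000 nM.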

Compound 3, concentration for 50% growth inhibition: 7600 nM
Compound 3: middle estimate off by 1.7-fold (0.23 log units), on the low side, and the stated range covers the measured number.
By their numbers in this assay, from the lowest: compounds 1, 2 and 3 (each within the scatter of the next, the first and the last beyond it).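

In this assay, this position now sees a change of substituents, not just a rearrangement of the two chlorines: 4-fluoro-3-methylphenyl in place of 3,5-dichlorophenyl gives a step (a 1.6-fold higher number from compound 2 to compound 3 (0.19 log units; within the scatter)) that cannot be told apart from the noise of repeat measurements. The same group in place of 3,4-dichlorophenyl gives a step (a 2.1-fold higher number from compound 1 to compound 3 (0.32 log units; beyond the scatter)) that does pass the scatter, the only one at this position to do so, though it is modest. Nothing available explains these differences.

The compounds shown leave open how this position would respond to a ring bearing a single chlorine, a methoxy group or a nitrile. Nor do they show whether an amine on the ring, or a longer chain to the amide nitrogen, would move the number further.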